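Swapping a lactam for a benzylamine on a naphthalene sulfonamide

This account rests on a few compounds, and the source may have more. Where it says the series, first, only, none or still open, it means among the compounds named here.

Compound 1 `Cc1noc(NS(=O)(=O)c2cccc3c(N4CCCCC4=O)cccc23)c1C` is the reference point. In an assay on VSM-A10 cells for antagonist activity at Endothelin-1 receptor (Rattus norvegicus) (a lower number here means a stronger inhibitor, a higher number a weaker inhibitor), compound 1 gives 270 nM, the lowest of the two numbers at hand. Its nearest neighbour, compound 3 `Cc1noc(NS(=O)(=O)c2ccc(F)cc2)c1C`, gives 1000 nM in this assay, a gap beyond the usual scatter. Compound 2 `Cc1noc(N(CC(=O)O)S(=O)(=O)c2ccc(N)cc2)c1C` reaches only the limit of this assay, > 32000 nM, so no number is known for it (the limit of > 32000 nM in this assay, at which 1 of the 3 values shown sits).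

The new compound 4 `Cc1noc(NS(=O)(=O)c2cccc3c(NCc4ccccc4)cccc23)c1C` differs from compound 1 in one place: benzylamino in place of 2-oxopiperidin-1-yl on an aromatic carbon. Among the measured compounds shown here, no measured pair shows this kind of change, so the expected step is modest and toward a lower number, a 1.8-fold lower number from compound 1 to compound 4 (0.26 log units; within the scatter), which is close to the scatter. Compound 4 is therefore estimated at 150 nM in this assay, with a range from 30 nM to 800 nM.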

Compound 4, half-maximal inhibitory concentration: 590 nM
For compound 4 the middle estimate is 3.9-fold (0.59 log units) below the measured one; the range from low to high includes it.
By their numbers in this assay, from the lowest: compound 1; then compounds 4 and 3 (each within the scatter of the next). At a limit, above all of these: compound 2.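

Among the compounds shown here, at this aromatic carbon, the first direct comparison in this assay shows that benzylamino in place of 2-oxopiperidin-1-yl gives a modest loss: a 2.2-fold higher number from compound 1 to compound 4 (0.34 log units; beyond the scatter). The step stays modest although a non-aromatic ring with a carbonyl gives way to an aromatic ring and a hydrogen-bond donor, so this position accepts both of these quite different groups. For the compounds shown here, nothing measured so far explains the direction or size of this step. Going by these compounds, whether a plain amine or a longer chain at this position would give a lower or a higher number remains open.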